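The source may report more compounds than this note shows. Statements on the series, on what has been measured and on what is new or still open speak of the compounds shown alone.

Measured so far in a functional assay on the whole organism (Abdomen, strain albino) for inhibition, with Mus musculus as the target, with stated times of 1 h and 60 min, at a dose of 100 umol/kg by the oral route; on this read-out lower numbers stand for less inhibition and higher numbers for more inhibition at the one dose given (going by the name of the read-out):
compound 1 `Cc1c(C(=O)N/N=C/c2ccc(N(C)C)cc2)no[n+]1[O-]` gives 22%
compound 2 `Cc1c(C(=O)N/N=C/c2cccs2)no[n+]1[O-]` gives 14%
compound 3 `Cc1c(C(=O)N/N=C/c2ccc(C(=O)O)cc2)no[n+]1[O-]` gives 0%

Compound 3 stands lowest of the three numbers. Its nearest neighbour is compound 2, which sits higher by a gap beyond the scatter, and the furthest is compound 1, higher still, again beyond the scatter. For the measured compounds named here, the only step within the measured set is a number 22 percentage points lower from compound 1 to compound 3 (beyond the scatter), which came with carboxy in place of dimethylamino on an aromatic carbon.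

Compound 4 `Cc1c(C(=O)N/N=C/c2ccc(Br)cc2)no[n+]1[O-]` is not yet measured. Against compound 3 the change is bromo in place of carboxy on an aromatic carbon. Going by the values given here, no measured step exchanges carboxy for bromo, so nothing bears on this change directly. Among the compounds with values here, what is known is only that the carboxy-bearing compound 3 gives the lowest number and that the step of a number 22 percentage points lower from compound 1 to compound 3 (beyond the scatter) was a modest fall when carboxy entered; on that basis the carboxy leaving is expected to give a modest rise in this assay, estimated as a number 12 percentage points higher from compound 3 to compound 4 (beyond the scatter), though with wide uncertainty. Compound 4 is accordingly estimated at 12%, with a range from 0% to 28%.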

Compound 4, a percentage reported as inhibition, in the whole organism at one dose (the size of the read-out at that dose, not a potency): 23%
Estimate against measurement, compound 4: 11 percentage points below; the range from low to high includes it.
By their numbers in this assay, from the lowest: compound 3; then compounds 2, 1 and 4 (each within the scatter of the next).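

In this assay, the step of a number 23 percentage points higher from compound 3 to compound 4 (beyond the scatter) shows that a group other than dimethylamino on this aromatic carbon can also give a number clearly above that of the carboxy compound. The step of a number 1 percentage points higher from compound 1 to compound 4 (within the scatter) leaves bromo and dimethylamino within the scatter of each other, so among the three groups compared at this position, only carboxy stands apart. Nothing measured here bears on why the carboxy compound differs from the other two.

Open, from the compounds shown here alone, is whether a methyl ester or a primary amide on this carbon would group with carboxy or with bromo and dimethylamino. Going by these compounds, the numbers in this assay also come from a single dose, so how these compounds compare in potency remains open.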